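Hydroxy in place of methoxy across two hydrazide cores

This account rests on a few compounds, and the source may have more. Where it says the series, first, only, none or still open, it means among the compounds named here.

Measured so far:
compound 1 `O=C(N/N=C/c1ccc(-c2ccc(F)cc2F)o1)c1ccccc1O`: 63.4%
compound 2 `COc1ccccc1C(=O)N/N=C/c1ccc(-c2ccc(F)cc2F)o1`: 1.69%
compound 3 `COc1ccccc1/C=N/NC(=O)c1ccc(-c2ccc(F)cc2F)o1`: 53.1%

In a functional assay on Bel-7402 cells (Homo sapiens) for inhibition, read by sulforhodamine B assay, with a stated time of 48 h, tested at 10 uM (a lower number here means less inhibition of growth, a higher number more inhibition of growth at the concentration tested), compound 1 gives 63.4%, compound 2 gives 1.69% and compound 3 gives 53.1%. Going by the values given here, the one change seen within the measured set is hydrogen in place of methyl on an oxygen on an aromatic ring, which produced a number 61.7 percentage points higher from compound 2 to compound 1 (beyond the scatter). Compound 4 `O=C(N/N=C/c1ccccc1O)c1ccc(-c2ccc(F)cc2F)o1` carries the same change on the core of compound 3, (hydrogen in place of methyl on an oxygen on an aromatic ring); the place is worded identically in both cases, so it is the same change, though on a different core. The difference between the cores of compound 3 and compound 2 is not broken down here. Among the compounds with values here, with only one precedent, a smaller rise is expected, a number 21.9 percentage points higher from compound 3 to compound 4 (beyond the scatter), because compound 3 already stands at 53.1% in this assay. Compound 4 is thus expected near 75%. The span for compound 4 is estimated from 50% to 95%.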

Compound 4, percent growth inhibition at one concentration: 91.8%
Compound 4: the middle estimate sits 16.8 percentage points below what was measured, within the range that was stated.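

In this assay, hydroxy in place of methoxy again gives more growth inhibition, with a number 38.7 percentage points higher from compound 3 to compound 4 (beyond the scatter), so the direction of the step holds on the second core. Its size does not carry over unchanged: the same change on two cores in this assay, a number 61.7 percentage points higher (beyond the scatter) from compound 2 to compound 1 and a number 38.7 percentage points higher (beyond the scatter) from compound 3 to compound 4, 23 percentage points apart, beyond the scatter of two such steps. These two cores show only that the direction was shared; they do not explain the gap in size or show what the step would be on a further core.

Still open, as far as these compounds go, is whether a free hydroxy is needed for the gain, or whether an amine or a carboxylic acid in its place would read alike in this assay. A longer chain on the oxygen, such as ethyl, would show whether methyl is a special case.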